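A few compounds are considered here, and "the series" means these few. Any claim that something is new, unique, unknown or untested is made for them only; others in the source may bear on it.

Of the compounds shown here, three built on a shared core have been measured in a functional assay on the whole organism for inhibition of sodium-dependent dopamine transporter (Mus musculus); on this read-out lower numbers stand for an effect already at smaller amounts and higher numbers for an effect only at larger amounts of compound. Compound 1 `CCCCNC(=O)Nc1cccc2c1CN(C)CC2c1ccc(Cl)cc1` gives about 120 mg/kg. Compound 2 `CCCCNC(=O)Nc1cccc2c1CN(C)CC2c1ccc(C)cc1` differs from compound 1 by methyl in place of chloro on an aromatic carbon. In this assay compound 2 reached only a limit, namely > 100 mg/kg. The step that the limit leaves unreadable from compound 1 to compound 2 is therefore not readable, since one of its two values is the limit of > 100 mg/kg in this assay, at which 1 of the 3 values shown sits. Compound 3 `CCNCC(=O)Nc1cccc2c1CN(C)CC2c1ccc(Cl)cc1` differs from compound 1 by (ethylamino)methyl in place of butylamino on a carbonyl carbon; in this assay compound 3 gives about 25 mg/kg, and this step is a 4.8-fold lower number from compound 1 to compound 3 (0.68 log units; beyond the scatter). For the measured compounds named here, compound 4 `CCNCC(=O)Nc1cccc2c1CN(C)CC2c1ccc(C)cc1` has not yet been measured in this assay; it differs from compound 3 by methyl in place of chloro on an aromatic carbon, the same change, at the same place, as the one from compound 1 to compound 2. Since the earlier step that the limit leaves unreadable from compound 1 to compound 2 gives no size, the direction alone suggests a weaker effect, and for compound 4 the expected step is a 2.4-fold higher number from compound 3 to compound 4 (0.38 log units; beyond the scatter), held with wide uncertainty. Compound 4 is thus estimated at about 60 mg/kg, somewhere between 25 mg/kg and 150 mg/kg.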

Compound 4, dose for half-maximal effect: about 15 mg/kg
For compound 4 the middle estimate is 4.0-fold (0.60 log units) above the measured one; measured number below the stated range.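

In this assay, methyl in place of chloro on the aromatic carbon gives a 1.7-fold lower number from compound 3 to compound 4 (0.22 log units; within the scatter), which stays within the scatter; the same change between the two butylamino compounds cannot be read, so these compounds do not show whether this change carries from one core to the other. The other change, (ethylamino)methyl in place of butylamino on the carbonyl carbon, gives an at least 6.6-fold lower number from compound 2 to compound 4 (0.82 log units; beyond the scatter) and lowers the number on both the chloro and the methyl compounds, so its direction carries across these two cases, but whether its size does remains undecided: the same change on two cores in this assay, a 4.8-fold lower number (0.68 log units; beyond the scatter) from compound 1 to compound 3 and an at least 6.6-fold lower number (0.82 log units; beyond the scatter) from compound 2 to compound 4; the limit leaves it open whether they differ. Compound 2 gives only a limit, > 100 mg/kg, and no number: the limit of > 100 mg/kg in this assay, at which 1 of the 4 values shown sits.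

The compounds shown leave open how a fluoro or methoxy group on the same aromatic carbon would compare with chloro and methyl. They also leave open whether a longer chain on the amine, or a cyclic amine such as piperidine in place of the ethylamino group, would shift the read-out further.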